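The compounds below may be only part of what the source reports. "The series", "measured", "known", "first", "only" and "open" are said of these compounds alone.

Measured so far:
compound 1, `COc1ccc2nc(C)c(NC(=O)C(=O)Nc3cc(C)cc(C)c3)c(O)c2c1` — > 100000 nM
compound 2, `COc1ccc2nc(C)cc(OCC(=O)Nc3cc(C)ccc3C)c2c1` — > 100000 nM

In a toxicity assay on HepG2 cells (Homo sapiens) for inhibition, read by CellTiter-Glo, with a stated time of 48 h (on this read-out higher numbers stand for weaker inhibition and lower numbers for stronger inhibition), compound 1 gives only a limit, > 100000 nM. In this assay compound 2 likewise gives only a limit, > 100000 nM. Compound 2 thus has no fixed position on the numbers shown: every value here sits at the limit of > 100000 nM in this assay, at which 2 of the 2 values shown sit.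

Compound 3, `COc1ccc2nc(C)cc(OCC(=O)Nc3noc(C)c3C)c2c1`, is not yet measured. Its change from compound 2: 4,5-dimethyl-1,2-oxazol-3-yl in place of 2,5-dimethylphenyl on an amide-type nitrogen. Among the measured compounds shown here, no step between measured compounds is known, so no size can be read off. The expected step from compound 2 to compound 3 in this assay is none beyond the scatter, a number no higher from compound 2 to compound 3 (the limit leaves the size open). Compound 3 is expected to give about 100000 nM, from 30000 nM to 300000 nM, most probably again as a limit.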

Compound 3, half-maximal inhibitory concentration: > 100000 nM
Compound 3 gave a limit, no number; the forecaster's own chance of this, stated with the estimate: 85%; the middle value sits exactly at the limit.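

In this assay, among the compounds shown here, compound 2 and compound 3 both give only limits, so no step between them can be read. The compounds shown leave open whether 4,5-dimethyl-1,2-oxazol-3-yl in place of 2,5-dimethylphenyl changes the read-out at all in this assay.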